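The source may hold more compounds than are shown below. What is called first, only, known or untested is meant among the compounds shown, and "the series" means these compounds.

Measured in an ADME assay on Vero cells (Chlorocebus sabaeus) for cytotoxicity, read by MTT assay, with a stated time of 72 h; on this read-out lower numbers stand for higher toxicity in this test and higher numbers for lower toxicity in this test:
- compound 1 `CC1(C)C=Cc2c(ccc(C(=O)/C=C/c3ccc(F)cc3)c2O)O1`: 158000 nM
- compound 2 `CC1(C)C=Cc2c(ccc(C(=O)/C=C/c3cc(C=O)ccc3O)c2O)O1`: "not determined" (no result reported)

Going by the values given here, compound 1, at 158000 nM, holds the only number in this small set, so it cannot be ranked against anything. For compound 2 the entry reads "not determined" (no result reported), which leaves no second number for comparison.

The next compound to be tested is compound 3 `CC1(C)C=Cc2c(ccc(C(=O)/C=C/c3cccnc3)c2O)O1`. It keeps the core of compound 1 but carries pyridin-3-yl in place of 4-fluorophenyl on a double-bonded chain carbon bound to a double-bonded chain carbon.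

Among the compounds with values here, no pair of measured compounds shows what a change of this kind does in this assay, so the data offer no direction for it. Within the data shown here, the only guide is compound 1 at 158000 nM, and the expectation therefore stays close to that number, with no change beyond the usual scatter. The expected size of the change is a 1.1-fold lower number from compound 1 to compound 3 (0.02 log units; within the scatter). The estimated value for compound 3 is 150000 nM, with an expected range from 50000 nM to 400000 nM.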

Compound 3, half-maximal cytotoxic concentration: 8600 nM
Compound 3: middle estimate off by 17-fold (1.24 log units), on the high side, outside the stated range (below it).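

In this assay, swapping 4-fluorophenyl for pyridin-3-yl on a double-bonded chain carbon bound to a double-bonded chain carbon gives an 18-fold lower number from compound 1 to compound 3 (1.26 log units; beyond the scatter), which means higher toxicity in this test. Going by these compounds alone, this is the first measured step at this position, and it shows that the position is not a silent one: with the shared core unchanged, exchanging one six-membered aromatic ring for another that holds a single hetero atom moves the read-out well beyond the usual scatter. Nothing measured here shows what lies behind this shift, so the result stands as an observation and not as an explanation.

The compounds shown leave open whether the step follows from gaining the ring nitrogen or from losing the fluorine, and a plain phenyl group at the same place would help to separate those two possibilities. Also open, going by these compounds, are whether pyridin-4-yl, with its ring nitrogen placed differently, would give a similar number and how a ring carrying an amine or a carboxylic acid would behave at this position.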